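The source may report more compounds than this note shows. Statements on the series, on what has been measured and on what is new or still open speak of the compounds shown alone.

Three compounds have so far been measured in a functional assay on the whole organism (strain Swiss) with Mus musculus as the target, in the maximal electroshock model, with a stated time of 0.5 h, at a dose of 300 mg/kg by the intraperitoneal route; a higher number here means a stronger effect of the compound at the dose given, a lower number a weaker effect:

compound 1, `CCC(C(=O)N1CCN(c2ccccc2F)CC1)N1C(=O)CCC1=O`, gives 100%
compound 2, `CC(C(=O)N1CCN(c2cccc(Cl)c2)CC1)N1C(=O)CCC1=O`, gives 100%
compound 3, `CC(C(=O)N1CCN(c2ccc(Cl)cc2)CC1)N1C(=O)CCC1=O`, gives 100%

Compound 3 stands level with compound 1 and compound 2 at the digits reported; its nearest neighbour is compound 1 and its furthest is compound 2, and neither gap reaches beyond the scatter. Within the data shown here, the only measured step with one change, no change at the digits printed from compound 2 to compound 3 (within the scatter), shows that exchanging the group on an amine nitrogen in a ring left the read-out where it was.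

Compound 4, `CC(C(=O)N1CCN(c2ccccc2F)CC1)N1C(=O)CCC1=O`, differs from compound 3 in one place: 2-fluorophenyl in place of 4-chlorophenyl on an amine nitrogen in a ring. Among the measured compounds shown here, this step also exchanges the group on an amine nitrogen in a ring, as the step from compound 2 to compound 3 did, and the group that enters is the one that compound 1 already carries, where compound 1 gives 100%. No step beyond the scatter is therefore expected, no change at the digits printed from compound 3 to compound 4 (within the scatter). Compound 4 is estimated to give 100% in this assay, with an expected range from 85% to 100%.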

Compound 4, a percentage reported as activity, at one dose (the size of the read-out at that dose, not a potency): 50%
Beside the measured number, compound 4's estimate is 50 percentage points above it, outside the stated range (below it).
By their numbers in this assay, from the lowest: compound 4; then compounds 1, 2 and 3 (each within the scatter of the next).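

In this assay, the group on the amine nitrogen in a ring proves not to be freely exchangeable: 2-fluorophenyl in place of 4-chlorophenyl gives a large fall (a number 50 percentage points lower from compound 3 to compound 4 (beyond the scatter)), and 2-fluorophenyl in place of 3-chlorophenyl gives another (a number 50 percentage points lower from compound 2 to compound 4 (beyond the scatter)), whereas the exchange between the two chlorophenyl groups did not move the read-out (no change at the digits printed from compound 2 to compound 3 (within the scatter)). The 2-fluorophenyl group does not settle the outcome alone, since hydrogen in place of methyl on a saturated chain carbon, two bonds along the chain from an amide-type nitrogen in a ring and a carbonyl carbon, also gives a large fall (a number 50 percentage points lower from compound 1 to compound 4 (beyond the scatter)). No evidence at hand accounts for either fall.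

On these data alone, whether 2-chlorophenyl or 4-fluorophenyl on that nitrogen would hold the read-out remains open, as does the effect of a longer chain, such as propyl, on the chain carbon. With compounds 1, 2 and 3 level at this single dose, any differences among them also stay unresolved.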